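Halogen swap at the aromatic carbon: compound 3 to compound 4

The compounds below may be only part of what the source reports. "The series", "measured", "known", "first", "only" and "open" are said of these compounds alone.

Measured so far in an ADME assay on microsomes from liver (Homo sapiens) for metabolic stability, read by LC-MS, with a stated time of 15 min, tested at 1 uM, in the presence of a further agent that is not named here; on this read-out lower numbers stand for a less stable compound and higher numbers for a more stable compound:
compound 1 `CCc1nc(N)nc2c1c(-c1ccc3oc(N)nc3c1)nn2C(C)C` gives 93%
compound 2 `CC(C)n1nc(-c2ccc3oc(N)nc3c2)c2c(CO)nc(N)nc21` gives > 95%, which is a limit of this assay
compound 3 `CC(C)n1nc(-c2ccc3oc(N)nc3c2)c2c(Cl)nc(N)nc21` gives 92%

Compound 3 holds the lowest of the two numbers, with compound 1 nearest at a number 1 percentage points lower from compound 1 to compound 3 (within the scatter); the remaining value is a limit (the limit of > 95% in this assay, at which 1 of the 3 values shown sits). Compound 4 `CC(C)n1nc(-c2ccc3oc(N)nc3c2)c2c(Br)nc(N)nc21` differs from compound 3 only by bromo in place of chloro on an aromatic carbon. Within the data shown here, the steps into compound 3 were a number 1 percentage points lower from compound 1 to compound 3 (within the scatter) and a number at least 3 percentage points lower from compound 2 to compound 3 (that floor lies within the scatter), so exchanges at this carbon have stayed within the scatter; no measured step involves bromo. For compound 4 a step of a number 2 percentage points lower from compound 3 to compound 4 (within the scatter) is therefore expected, none beyond the scatter. Compound 4 is estimated at 90%, between 78% and 96%.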

Compound 4, percent of the compound remaining: 94%
Beside the measured number, compound 4's estimate is 4 percentage points below it, and the stated range covers the measured number.
By their numbers in this assay, from the lowest: compounds 3, 1 and 4 (each within the scatter of the next). At a limit, above all of these: compound 2.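

In this assay, exchanging chloro for bromo on this aromatic carbon next to the ring nitrogen gives a number 2 percentage points higher from compound 3 to compound 4 (within the scatter), and the comparison with ethyl gives a number 1 percentage points higher from compound 1 to compound 4 (within the scatter). Bromo therefore joins chloro and ethyl as a third group at this carbon that this read-out does not separate. Against hydroxymethyl the step is a number at least 1 percentage points lower from compound 2 to compound 4 (that floor lies within the scatter), and compound 2 stands at a limit, so that step has no exact size: the limit of > 95% in this assay, at which 1 of the 4 values shown sits.

Still open, as far as these compounds go, is whether an amine, a carboxylic acid or a longer chain on this carbon would move the reading beyond the scatter.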